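The compounds below may be only part of what the source reports. "The series", "measured", "known", "first", "only" and "open" are said of these compounds alone.

Measured compounds in a functional assay on MCF7 cells (Homo sapiens) for antiproliferative activity, read by CCK-8 assay, with a stated time of 48 h; a higher number here means a weaker inhibitor, a lower number a stronger inhibitor:

- compound 1, `COc1ccc2[nH]c(C)c(C3=C(Br)C(=O)C(c4c(-c5ccccc5)[nH]c5ccccc45)=C(Br)C3=O)c2c1`, gives 2.57 ug/mL
- compound 2, `COc1ccc2[nH]c(C)c(C3=C(Br)C(=O)C(c4c(-c5ccc(C)cc5)[nH]c5ccccc45)=C(Br)C3=O)c2c1`, gives 2.56 ug/mL
- compound 3, `Cc1[nH]c2ccccc2c1C1=C(Br)C(=O)C(Br)=C(c2c(-c3ccccc3)[nH]c3ccccc23)C1=O`, gives 3.02 ug/mL

Compound 1 and compound 2 share one core and differ by methyl in place of hydrogen on an aromatic carbon. That change gave a 1.0-fold lower number from compound 1 to compound 2 (0.00 log units; within the scatter). Compound 3 carries a different core; the difference between the core of compound 1 and the core of compound 3 is not broken down here, and the two values of compound 1 and compound 3 lie within the scatter of each other.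

Compound 4, `Cc1ccc(-c2[nH]c3ccccc3c2C2=C(Br)C(=O)C(Br)=C(c3c(C)[nH]c4ccccc34)C2=O)cc1`, is not yet measured. Among the measured compounds shown here, it differs from compound 3 by methyl in place of hydrogen on an aromatic carbon, the same kind of change as the one from compound 1 to compound 2, at a place described in the same words. For the measured compounds named here, since that earlier step was flat, the expected step from compound 3 to compound 4 in this assay is also flat, a 1.0-fold lower number from compound 3 to compound 4 (0.00 log units; within the scatter), which rests on the one paired step from compound 1 to compound 2 alone. Compound 4 is therefore estimated at 3 ug/mL, with a likely range from 1.8 ug/mL to 5 ug/mL.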

Compound 4, half-maximal inhibitory concentration: 6.85 ug/mL
Estimate against measurement, compound 4: 2.3-fold (0.36 log units) below; measured number outside the range, above it.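

In this assay, phenyl to 4-methylphenyl gives a 2.3-fold higher number from compound 3 to compound 4 (0.36 log units; beyond the scatter), while the same change on the core of compound 1 stayed flat at a 1.0-fold lower number from compound 1 to compound 2 (0.00 log units; within the scatter). Set side by side, the two steps cannot be told apart, so the data do not show that the core alters the outcome of this change: the same change on two cores in this assay, a 1.0-fold lower number (0.00 log units; within the scatter) from compound 1 to compound 2 and a 2.3-fold higher number (0.36 log units; beyond the scatter) from compound 3 to compound 4, 2.3-fold (0.36 log units) apart, within the scatter of two such steps. Nor do two pairs show that the change carries over unaltered from one core to another, and they fix no reliable size for it beyond these compounds.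

The compounds shown leave open whether another group in place of the methyl, such as an amine, a carboxylic acid or a longer chain, would give steps that do differ between the two cores. Among the compounds shown here, also open is how the core of compound 1 and the core of compound 3 compare on their own, since no single-place step links them here.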